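The source may hold more compounds than are shown below. What is called first, only, known or untested is meant among the compounds shown, and "the series" means these compounds.

Among the compounds with values here, in a functional assay on THP-1 cells (Homo sapiens) for inhibition, read by sulforhodamine B assay, with a stated time of 48 h, tested at 50 uM (on this read-out lower numbers stand for less inhibition of growth and higher numbers for more inhibition of growth at the one concentration tested), two compounds have numbers so far. Compound 2 `COc1cc(/C=C/C(=O)/C=C/c2cc(OC)c(OC)c(OC)c2)ccc1OCc1cn(CCCCCOc2cc(=O)oc3ccccc23)nn1` gives 55%, the lowest of the two; compound 1 `COc1cc(/C=C/C(=O)/C=C/c2cc(OC)c(OC)c(OC)c2)ccc1OCc1cn(CCOc2cc(=O)oc3ccccc23)nn1` gives 99%, a gap beyond the usual scatter. Compound 3 `COc1cc(/C=C/C(=O)/C=C/c2cccs2)ccc1OCc1cn(CCCCCOc2cc(=O)oc3ccccc23)nn1` has not been measured. It differs from compound 2 in one place: thiophen-2-yl in place of 3,4,5-trimethoxyphenyl on a double-bonded chain carbon bound to a double-bonded chain carbon. Within the data shown here, no measured pair shows this kind of change, so no step can be read from the data. The step from compound 2 to compound 3 in this assay is expected to be small and downward, a number 10 percentage points lower from compound 2 to compound 3 (within the scatter), though a change within the scatter is also plausible. Compound 3 is therefore estimated at 45%, in a range from 20% to 75%.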

Compound 3, percent growth inhibition at one concentration: 34%
Compound 3: the middle estimate sits 11 percentage points above what was measured; low and high end bracket the measured number.
By their numbers in this assay, from the lowest: compound 3; then compound 2; then compound 1.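

In this assay, putting thiophen-2-yl in place of 3,4,5-trimethoxyphenyl on a double-bonded chain carbon bound to a double-bonded chain carbon gives a number 21 percentage points lower from compound 2 to compound 3 (beyond the scatter). This position is therefore sensitive to the group it carries, and this five-membered sulfur ring does not keep the growth inhibition seen with the trimethoxylated six-membered ring. Nothing available gives a reason for the drop. On these data alone, whether the same swap would also lower the number on the core of compound 1 stays open. As far as these compounds go, it is also open whether an unsubstituted phenyl or a furan-2-yl group would land nearer compound 2 or compound 3.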